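The compounds below may be only part of what the source reports. "The series", "measured", "known", "first", "only" and "open" are said of these compounds alone.

Among the measured compounds shown here, compound 2 `CC1(C)[C@H](C(=O)OCc2ccc(C(=O)O)cc2)N2C(=O)[C@H](NC(=O)C(F)(F)F)[C@@H]2[S+]1[O-]` is the one compound with an actual number in a physicochemical assay; a higher number here means that the compound lasts longer, a lower number that the compound disappears faster: compound 2 gives 5.3 h. Compound 1 `CO[C@H]1C(=O)N2[C@@H](C(=O)OCc3ccc(C(=O)O)cc3)C(C)(C)S(=O)(=O)[C@H]12` is reported in this assay only as a limit, compound 1 giving < 1 h, which is the limit of < 1 h in this assay, at which 1 of the 2 values shown sits. For the measured compounds named here, no pair of measured compounds differs in a single place, so the size of any single change cannot be read from these two results.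

Compound 3 `CC1(C)[C@H](C(=O)OCc2ccc(C(=O)O)cc2)N2C(=O)[C@H](NC(=O)C(F)(F)F)[C@H]2[S+]1[O-]` has not yet been measured in this assay. It differs from compound 2 in one stereocentre only: the two compounds have the same atoms and bonds; at least one stereo element is drawn with a configuration in one of them and without one in the other: 1 of 4 stereo elements differ; a stereocentre at a saturated ring carbon is drawn S in compound 2 and R in compound 3. Going by the values given here, with no measured step of this kind to lean on, the account expects no shift beyond the usual scatter for the step from compound 2 to compound 3, estimated at a 1.5-fold lower number from compound 2 to compound 3 (0.18 log units; within the scatter). Compound 3 is therefore expected to give about 3.5 h in this assay, with a range from 1.2 h to 10 h.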

Compound 3, half-life: 1.4 h
Compound 3: middle estimate off by 2.5-fold (0.40 log units), on the high side; the measured number falls inside the stated range.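

In this assay, a stereocentre at a saturated ring carbon now has a measured effect of its own: with atoms and bonds unchanged, going from S to R gives a 3.8-fold lower number from compound 2 to compound 3 (0.58 log units; beyond the scatter). Among the compounds shown here, the earlier compounds offered no single-place comparison, so this is the first evidence that configuration alone at this carbon can shift the half-life beyond the usual scatter, even though it rests on one pair. One caution attaches to how the change is read: the fact that one of compounds 2 and 3 is drawn with a defined configuration and the other without, at the place where they differ

The compounds shown do not reveal how this configuration changes the half-life, and they give no second pair at this stereocentre. From the compounds shown here alone, whether a step of similar size would appear with a free amine in place of the amide bearing the trifluoromethyl group remains open.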